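Pyrrolidin-1-yl in place of 4-(pyridin-2-yl)piperazin-1-yl

This account rests on a few compounds, and the source may have more. Where it says the series, first, only, none or still open, it means among the compounds named here.

Of the compounds shown here, three sharing one core have been measured so far in a functional assay on PC-3 cells (Homo sapiens) for inhibition, read by MTT assay, with a stated time of 48 h (on this read-out higher numbers stand for weaker inhibition and lower numbers for stronger inhibition), on PC-3 cells. Compound 1 `COc1ccc(-c2coc3cc(OCCCSC(=S)N4CCN(C)CC4)ccc3c2=O)cc1` gives 2210 nM and compound 2 `COc1ccc(-c2coc3cc(OCCCSC(=S)N4CCN(C(C)=O)CC4)ccc3c2=O)cc1` gives 4310 nM on this scale, while compound 3 `COc1ccc(-c2coc3cc(OCCCSC(=S)N4CCN(c5ccccn5)CC4)ccc3c2=O)cc1` gives 17400 nM as the highest number of the three and the weakest inhibition. Compound 4 `COc1ccc(-c2coc3cc(OCCCSC(=S)N4CCCC4)ccc3c2=O)cc1` keeps the core but carries pyrrolidin-1-yl in place of 4-(pyridin-2-yl)piperazin-1-yl on a thiocarbonyl carbon and has not been measured. For the measured compounds named here, no measured pair makes this exact swap. The closest evidence lies on an amine nitrogen in a ring, where pyridin-2-yl in place of methyl gave a 7.9-fold higher number from compound 1 to compound 3 (0.90 log units; beyond the scatter) and pyridin-2-yl in place of acetyl gave a 4.0-fold higher number from compound 2 to compound 3 (0.61 log units; beyond the scatter) while acetyl in place of methyl gave a 2.0-fold higher number from compound 1 to compound 2 (0.29 log units; within the scatter) and nothing more. Compound 3 carries pyridin-2-yl at 17400 nM and compound 4 does not, so a modest step to a lower number is expected in this assay of a size near those two. The estimated move is a 3.5-fold lower number from compound 3 to compound 4 (0.54 log units; beyond the scatter) for now. Going by the values given here, no measured compound carries pyrrolidin-1-yl, so the range stays wide. For compound 4 the estimate is 5000 nM with an expected range from 1500 nM to 17000 nM overall.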

Compound 4, half-maximal inhibitory concentration: 19400 nM
Beside the measured number, compound 4's estimate is 3.9-fold (0.59 log units) below it; the measured number lies above the stated range.
By their numbers in this assay, from the lowest: compounds 1 and 2 (each within the scatter of the next); then compounds 3 and 4 (each within the scatter of the next).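

In this assay, the swap of 4-(pyridin-2-yl)piperazin-1-yl for the smaller pyrrolidin-1-yl on a thiocarbonyl carbon gives a 1.1-fold higher number from compound 3 to compound 4 (0.05 log units; within the scatter) and so shows no separation between these two groups at this position. Against the other two piperazine groups the same ring fares differently, with a 4.5-fold higher number from compound 2 to compound 4 (0.65 log units; beyond the scatter) for the change from 4-acetylpiperazin-1-yl and an 8.8-fold higher number from compound 1 to compound 4 (0.94 log units; beyond the scatter) for the change from 4-methylpiperazin-1-yl, so a smaller group on its own does not bring a lower number here. Nothing available explains these differences.

On these data alone, it remains open whether a piperidine or morpholine ring here would read like pyrrolidin-1-yl or like 4-methylpiperazin-1-yl. An open-chain diethylamino group and an unsubstituted piperazin-1-yl group would test the same question.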